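The source may hold more compounds than are shown below. What is called first, only, known or untested is meant among the compounds shown, and "the series" means these compounds.

The measured compounds:
Compound 1, `CC1CCN(c2c(S(=O)(=O)c3ccccc3)cnc3ccccc23)CC1`, in an assay on isolated protein for displacement of a labelled ligand from metabotropic glutamate receptor 5 (Homo sapiens), with a stated time of 60 min (on this read-out higher numbers stand for weaker inhibition and lower numbers for stronger inhibition), gives 108 nM.
Compound 2, `O=S(=O)(c1cccc(Cl)c1)c1cnc2cc(Cl)ccc2c1N1CCC(CO)CC1`, in this assay gives 30.9 nM.

Of these two numbers compound 1 holds the higher one, that is the weaker inhibition; compound 2 sits at a lower number, and the gap between them lies beyond the usual scatter of repeated measurements. The two differ in more than one place, so their pair shows only where each stands, not what any single change does.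

Compound 3, `O=S(=O)(c1ccccc1)c1cnc2ccccc2c1N1CCCCCC1`, has not yet been measured in this assay. It arises from compound 1 by one change: azepan-1-yl in place of 4-methylpiperidin-1-yl on an aromatic carbon. For the measured compounds named here, no measured pair shows a step of this kind, so the expectation rests on compound 1 alone and on the change itself. Because compound 1 gives 108 nM and the change keeps what is counted unchanged, only a small step is expected, and in this assay the estimated step is a 1.4-fold higher number from compound 1 to compound 3 (0.14 log units; within the scatter), towards a somewhat higher number, though a result within the scatter would not surprise. Compound 3 is therefore expected to give about 150 nM, within a range from 50 nM to 450 nM.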

Compound 3, inhibition constant: 310 nM
Beside the measured number, compound 3's estimate is 2.1-fold (0.32 log units) below it; the measured number falls inside the stated range.
By their numbers in this assay, from the lowest: compound 2; then compound 1; then compound 3.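

In this assay, this position, on an aromatic carbon opposite the ring nitrogen, responds to a change that leaves the counted features untouched: azepan-1-yl in place of 4-methylpiperidin-1-yl gives a 2.9-fold higher number from compound 1 to compound 3 (0.46 log units; beyond the scatter). The two groups have the same heavy atoms, hydrogen-bond donors, hydrogen-bond acceptors and net charge, so the step shows that the arrangement of those atoms matters here, as a seven-membered ring or as a six-membered ring bearing a methyl group, and not only their number. What lies behind this step remains unexplained, as no supporting measurement bears on it.

The compounds shown leave open whether the step goes with the larger ring or with the loss of the methyl group, a question that plain piperidin-1-yl, carrying no methyl group on a six-membered ring, could separate. They also leave open whether azepan-1-yl would give a step of similar size in the setting of compound 2, with its chloro groups, or whether a hetero atom added to the ring, as in morpholin-4-yl, would be tolerated at this position.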